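Methyl-to-methoxy swap on the aryl ketone series

The source may report more compounds than this note shows. Statements on the series, on what has been measured and on what is new or still open speak of the compounds shown alone.

Measured compounds in a functional assay on HEK293 cells for antagonist activity at G-protein coupled receptor 52 (Homo sapiens), read by cAMP accumulation, with stated times of 15 min and 30 min; on this read-out lower numbers stand for stronger inhibition and higher numbers for weaker inhibition:
- Compound 1, `O=C(/C=C/CCc1ccc(Br)cc1)c1ccccc1`, gives 1810 nM.
- Compound 2, `Cc1cccc(C(=O)/C=C/CCc2ccccc2)c1`, gives 2570 nM.
- Compound 3, `Cc1ccc(C(=O)/C=C/CCc2ccccc2)cc1`, gives 3020 nM.

All three measured compounds sit close together; the numbers of compound 2 and compound 3 fall within the scatter of each other, and the gap from compound 2 to compound 1 is likewise within the scatter, so no ordering of the three can be claimed. Compound 2 has the second-highest number of the three, with compound 3 nearest and compound 1 furthest.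

The next compound, compound 4, `COc1cccc(C(=O)/C=C/CCc2ccccc2)c1`, keeps the shared core of compound 2 and differs from it in one place: methoxy in place of methyl on an aromatic carbon. Going by the values given here, no step between two measured compounds matches this change, so there is nothing in the set that tells what a methoxy in place of methyl does here. The three measured numbers show that small changes on the aryl ketone ring have so far kept the read-out in a narrow band.

The expectation for this assay is therefore no step beyond the scatter, in either direction, with the estimated step of a 1.0-fold higher number from compound 2 to compound 4 (0.01 log units; within the scatter). Compound 4 is estimated at 2600 nM, with a range from 1000 nM to 7000 nM.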

Compound 4, half-maximal inhibitory concentration: 1490 nM
For compound 4 the middle estimate is 1.7-fold (0.24 log units) above the measured one, within the range that was stated.
By their numbers in this assay, from the lowest: compounds 4, 1, 2 and 3 (each within the scatter of the next, the first and the last beyond it).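

Going by these compounds alone, the swap of methoxy in place of methyl on an aromatic carbon, meta to a large group, is the only one-place step so far, and in this assay it reads as a 1.7-fold lower number from compound 2 to compound 4 (0.24 log units; within the scatter). At this position, a group of two heavy atoms carrying one hydrogen-bond acceptor therefore stands in for a group of one heavy atom with no acceptor without a step beyond the scatter, so neither a gain nor a loss can be claimed for the change. No measurement at hand bears on why the read-out responds in this way.

Still open, as far as these compounds go, is whether this aromatic carbon tolerates groups of a different kind, such as an amine or a carboxylic acid, or a longer chain such as ethoxy in place of methoxy, while staying within the scatter of the methyl and methoxy compounds. Also open, from the compounds shown here alone, is whether the same swap gives a comparable step at other places on the ring, since this single pair speaks for one position only.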